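This account rests on a few compounds, and the source may have more. Where it says the series, first, only, none or still open, it means among the compounds named here.

In an ADME assay on BJ cells (Homo sapiens) for cytotoxicity, read by MTT assay, with a stated time of 72 h (on this read-out lower numbers stand for stronger inhibition and higher numbers for weaker inhibition), compound 1 `COc1ccccc1CNc1ncnc2c1ncn2C1CCCCO1` gives > 100000 nM, a limit of the assay.
In this assay compound 2 `COc1cccc(CNc2ncnc3c2ncn3C2CCCCO2)c1` gives > 100000 nM, a limit.
In this assay compound 3 `COc1ccccc1CNc1ncnc2c1ncn2C1CCCO1` gives > 100000 nM, a limit.

The change 3-methoxyphenyl in place of 2-methoxyphenyl on a saturated chain carbon bound to a nitrogen on an aromatic ring gives a step that the two limits leave unreadable from compound 1 to compound 2. The two cores differ as oxolan-2-yl in place of oxan-2-yl on an aromatic nitrogen, which gives a step that the two limits leave unreadable from compound 1 to compound 3. Compound 4 `COc1cccc(CNc2ncnc3c2ncn3C2CCCO2)c1` is not yet measured; it arises from compound 3 by 3-methoxyphenyl in place of 2-methoxyphenyl on a saturated chain carbon bound to a nitrogen on an aromatic ring, the same change as from compound 1 to compound 2, at a place described in the same words. All three measured values sit at the limit of > 100000 nM in this assay, at which 3 of the 3 values shown sit, so the size of either step is not readable. For this assay the step of a number no higher from compound 3 to compound 4 (the limit leaves the size open) is expected to be small, resting on (the limit of > 100000 nM in this assay, at which 3 of the 3 values shown sit). Compound 4 is therefore estimated at 100000 nM, most likely again reported only as a limit.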

Compound 4, half-maximal inhibitory concentration: > 100000 nM
Compound 4: no number, only a limit; the forecaster's own chance of this, stated with the estimate: 85%; the middle value lies on the limit itself.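

Neither the step from compound 3 to compound 4 nor that from compound 2 to compound 4 can be read in this assay, since all four compounds rest on one limit: the limit of > 100000 nM in this assay, at which 4 of the 4 values shown sit.
The compounds shown leave open what size, if any, either change has.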